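Ethyl in Place of Benzylcarbamoyl on an Amine Nitrogen

The compounds below may be only part of what the source reports. "The series", "measured", "known", "first", "only" and "open" are said of these compounds alone.

Of the compounds shown here, two with a shared core have numbers so far. In a functional assay on HL-60 cells (Homo sapiens) for cytotoxicity, read by MTT assay, with a stated time of 96 h (on this read-out lower numbers stand for stronger inhibition and higher numbers for weaker inhibition), compound 1 `CC[C@H](N)C(=O)N[C@@H]1C(=O)N2[C@@H](CC[C@@H]1CNC(=O)NCc1ccccc1)CC[C@H]2C(=O)NC(c1ccccc1)c1ccccc1` gives 51000 nM and compound 2 `CC[C@H](N)C(=O)N[C@@H]1C(=O)N2[C@@H](CC[C@@H]1CCNC(=O)NCc1ccccc1)CC[C@H]2C(=O)NC(c1ccccc1)c1ccccc1` gives 83300 nM, which places compound 2 within the scatter of compound 1. Among the measured compounds shown here, the only measured step, a 1.6-fold higher number from compound 1 to compound 2 (0.21 log units; within the scatter), is small and leaves the benzylcarbamoyl group in place.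

Compound 3 `CCNCC[C@H]1CC[C@H]2CC[C@@H](C(=O)NC(c3ccccc3)c3ccccc3)N2C(=O)[C@H]1NC(=O)[C@@H](N)CC` differs from compound 2 at that group: ethyl in place of benzylcarbamoyl on an amine nitrogen, with ethyl in place of benzylcarbamoyl on an amine nitrogen. For the measured compounds named here, no measured compound shows the effect of this exchange, so the data give no direction for it. With only the small step of a 1.6-fold higher number from compound 1 to compound 2 (0.21 log units; within the scatter) to go on, no change beyond the scatter is expected in this assay, though the uncertainty is wide. The expected change is a 1.3-fold lower number from compound 2 to compound 3 (0.11 log units; within the scatter), a step within the scatter. For compound 3 the estimated value is 65000 nM, with an expected range from 20000 nM to 150000 nM.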

Compound 3, half-maximal inhibitory concentration: 62800 nM
Estimate against measurement, compound 3: 1.0-fold (0.01 log units) above; low and high end bracket the measured number.
By their numbers in this assay, from the lowest: compounds 1, 3 and 2 (each within the scatter of the next).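

In this assay, ethyl in place of benzylcarbamoyl on the amine nitrogen gives a 1.3-fold lower number from compound 2 to compound 3 (0.12 log units; within the scatter), and (ethylamino)methyl in place of (benzylcarbamoyl)amino gives a 1.2-fold higher number from compound 1 to compound 3 (0.09 log units; within the scatter). The earlier step changed only the chain and kept the benzylcarbamoyl group, whereas these two steps show that a far larger exchange at this position, which removes the six-membered aromatic ring and the carbonyl of that group, also stays within the scatter. Nothing among the data shown accounts for this outcome.

The compounds shown leave open whether any group on this nitrogen can move the number beyond the scatter, since all three compounds lie within the scatter of one another. A free amine, a carboxylic acid or a longer chain in place of ethyl would test this.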